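Dechlorination of compound 1 on the hepatoma cytotoxicity read-out

A few compounds are considered here, and "the series" means these few. Any claim that something is new, unique, unknown or untested is made for them only; others in the source may bear on it.

Measured so far:
compound 1, `O=C(CCSc1nnc(-c2ccncc2)s1)Nc1ccc(Cl)cc1`: in an ADME assay on HepG2 cells (Homo sapiens) for cytotoxicity, with a stated time of 3 days (on this read-out lower numbers stand for higher toxicity in this test and higher numbers for lower toxicity in this test), compound 1 gives 7260 nM.
compound 2, `CC(Sc1nnc(-c2ccncc2)s1)C(=O)NCc1ccccc1`: in this assay compound 2 reaches only the assay limit, > 50000 nM.

Among the measured compounds shown here, compound 1 carries the only numerical value in this assay; the other result, for compound 2, is a limit and not a number (the limit of > 50000 nM in this assay, at which 1 of the 2 values shown sits). Compound 3, `O=C(CCSc1nnc(-c2ccncc2)s1)Nc1ccccc1`, differs from compound 1 by hydrogen in place of chloro on an aromatic carbon. For the measured compounds named here, no step between measured compounds is available, so the size of this change in this assay is unanchored. A modest shift toward lower toxicity in this assay is expected, estimated as a 2.1-fold higher number from compound 1 to compound 3 (0.32 log units; beyond the scatter). Compound 3 is expected at 15000 nM, within 5000 nM to 50000 nM.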

Compound 3, half-maximal cytotoxic concentration: > 50000 nM
Compound 3: only a limit was reported; the forecaster's own chance of this, stated with the estimate: 30%; middle value at least 3.3-fold (0.52 log units) from the limit.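

Among the compounds shown here, replacing the chloro of the 4-chlorophenyl group with hydrogen gives the first anchored step at this position in this assay: an at least 6.8-fold higher number from compound 1 to compound 3 (0.83 log units; beyond the scatter). Compound 3 gives > 50000 nM, which is a limit and not a number, so the step fixes only a minimum size. Compound 1 is now the only compound in the series with a numerical value, and the rest of the read-out is bounded: the limit of > 50000 nM in this assay, at which 2 of the 3 values shown sit.

On these data alone, how far compound 3 lies beyond the limit remains open. Also open, as far as these compounds go, is whether a fluoro or methoxy group in place of the chloro would keep the read-out near that of compound 1.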